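A few compounds are considered here, and "the series" means these few. Any claim that something is new, unique, unknown or untested is made for them only; others in the source may bear on it.

Measured so far, in a functional assay on the whole organism (strain CD1) with Mus musculus as the target, in the maximal electroshock model, with a stated time of 0.5 h; a higher number here means that more compound is needed for the effect, a lower number that less compound is needed:

Compound 1 `CCC1(C)CC(=O)N(CC(=O)N2CCN(c3ccccc3Cl)CC2)C1=O` gives 100 mg/kg.
Compound 2 `CC1CC(=O)N(CC(=O)N2CCN(c3ccc(Cl)c(Cl)c3)CC2)C1=O` gives 300 mg/kg.
Compound 3 `CC1CC(=O)N(CC(=O)N2CCN(c3cccc(C(F)(F)F)c3)CC2)C1=O` gives 100 mg/kg.

Compound 2 stands at the highest number of the three in this assay; its gap to compound 1 and its gap to compound 3 are each beyond the scatter, so within this small set compound 2 needs the most compound for the effect. Compound 1 and compound 3 sit at the same number.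

The next compound, compound 4 `Cc1ccccc1N1CCN(C(=O)CN2C(=O)CC(C)C2=O)CC1`, differs from compound 2 in one place: 2-methylphenyl in place of 3,4-dichlorophenyl on an amine nitrogen in a ring. Within the data shown here, the 2-methylphenyl group that enters has no counterpart among the three measured compounds, so no measured step speaks directly to this change. The two measured neighbours of compound 2 both stand at a lower number, which suggests that compound 2 is the outlier of the series rather than the norm. The step from compound 2 to compound 4 is therefore expected to go to a lower number, of modest size, a 2.0-fold lower number from compound 2 to compound 4 (0.30 log units; within the scatter), possibly not beyond the scatter. Compound 4 is expected at 150 mg/kg, in the range 60 mg/kg to 400 mg/kg.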

Compound 4, minimum effective dose: 300 mg/kg
Beside the measured number, compound 4's estimate is 2.0-fold (0.30 log units) below it; low and high end bracket the measured number.
By their numbers in this assay, from the lowest: compounds 1 and 3 (each within the scatter of the next); then compounds 2 and 4 (each within the scatter of the next).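

In this assay, among these compounds, 2-methylphenyl in place of 3,4-dichlorophenyl on an amine nitrogen in a ring gives no change at the digits printed from compound 2 to compound 4 (within the scatter), the first step that can be read at this position. Compound 2 therefore no longer stands alone at its number: an aryl group of carbon only and one carrying two chlorine atoms read alike here on the shared core. No measurement at hand bears on why these two groups give the same reading.

On these data alone, whether the number at this position moves with other groups, such as an unsubstituted phenyl, a pyridine ring or a benzyl group, stays open. Also open, as far as these compounds go, is whether a longer chain elsewhere on the shared core would shift the number while 2-methylphenyl stays in place.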